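Replacing the ureido end of compound 3

The source may hold more compounds than are shown below. What is called first, only, known or untested is meant among the compounds shown, and "the series" means these compounds.

Going by the values given here, in an ADME assay on microsomes from liver (Mus musculus) for metabolic stability, using NADPH, with a stated time of 10 min (on this read-out higher numbers stand for a more stable compound and lower numbers for a less stable compound), compound 3 (`NC(=O)NCCCCN(C[C@H]1Cc2ncccc2CN1)[C@H]1CCCc2cccnc21`) gives 32% of its starting amount, the second highest of the three numbers measured so far. Compound 1 (`NCCCCN(C[C@H]1Cc2cccnc2CN1)[C@H]1CCCc2cccnc21`) stands higher at 69% and compound 2 (`CN(C[C@@H]1Cc2ncccc2CN1)[C@H]1CCCc2cccnc21`) stands lower at 0% in the same test, and both gaps to compound 3 lie beyond the usual scatter. These three compounds differ from one another in more than one place, so no single structural change can be read from them.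

Compound 4 (`CN(CCCCN(C[C@H]1Cc2ncccc2CN1)[C@H]1CCCc2cccnc21)C1CCOCC1`) has not yet been measured. It carries methyl(oxan-4-yl)amino in place of ureido on a saturated chain carbon, four bonds along the chain from an amine nitrogen. The guidance is thin. Among the measured compounds, a methyl on an amine occurs only in compound 2 at 0% and this points cautiously downward, although that compound also lacks the long chain. A moderate fall is therefore expected, with an estimated step of a number 12 percentage points lower from compound 3 to compound 4 (beyond the scatter) in this assay that remains quite uncertain. For compound 4 the estimated value is 20% with an expected range from 3% to 50% as its limits of confidence.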

Compound 4, percent of the compound remaining: 51%
Compound 4: the middle estimate sits 31 percentage points below what was measured; the measured number lies above the stated range.
By their numbers in this assay, from the lowest: compound 2; then compound 3; then compound 4; then compound 1.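

Going by these compounds alone, only compounds 3 and 4 differ in a single place, so this is the one clean comparison available: methyl(oxan-4-yl)amino in place of ureido on a saturated chain carbon, four bonds along the chain from an amine nitrogen, gives in this assay a modest step, a number 19 percentage points higher from compound 3 to compound 4 (beyond the scatter). The chain end can therefore carry the larger group, with 8 heavy atoms in place of 4, a six-membered non-aromatic ring and 0 hydrogen-bond donors in place of 2, without any loss on this read-out. No measurement shown here explains the step, and the size of the group, its ring and the loss of the donors all change together in this one swap.

On these data alone, it remains open whether the oxane ring or the methyl-bearing nitrogen matters more, and a dimethylamino end or an oxan-4-yl group placed directly on the chain would help to separate the two at this position. Also open, as far as these compounds go, is how much the chain itself contributes, which a shorter or longer chain ending in the same methyl(oxan-4-yl)amino group would show.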